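N-Hydroxylation of the pyridine amidine terminus

A few compounds are considered here, and "the series" means these few. Any claim that something is new, unique, unknown or untested is made for them only; others in the source may bear on it.

Compound 1 `N=C(N)N/N=C/c1cccc(C(=N)N)n1` is the reference member of the series. Among the compounds with values here, in an assay for inhibition of S-adenosylmethionine decarboxylase proenzyme (Rattus norvegicus) (on this read-out lower numbers stand for stronger inhibition and higher numbers for weaker inhibition), compound 1 gives 90 nM, the lowest number among the two compounds measured so far. Within the data shown here, its nearest neighbour is compound 2 `N=C(NO)N/N=C/c1cccc(C(=N)N)n1`, which in this assay gives 240 nM; the single step from compound 1 to compound 2 reads a 2.7-fold higher number from compound 1 to compound 2 (0.43 log units; beyond the scatter), a modest weakening that lies beyond the scatter.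

Compound 3 `N=C(N)N/N=C/c1cccc(C(=N)NO)n1` is not yet measured. It differs from compound 1 by hydroxy in place of hydrogen on an amine nitrogen, so the hydroxy now sits on the amidine terminus rather than on the guanidine side as in compound 2. Among the measured compounds shown here, the only measured step that bears on it is the one from compound 1 to compound 2, where the same change at the other amine nitrogen cost a 2.7-fold higher number from compound 1 to compound 2 (0.43 log units; beyond the scatter). A weakening of similar size is therefore expected for compound 3, with the step from compound 1 estimated as a 2.8-fold higher number from compound 1 to compound 3 (0.44 log units; beyond the scatter). On that basis compound 3 is expected to give about 250 nM in this assay, with a plausible range from 100 nM to 700 nM.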

Compound 3, half-maximal inhibitory concentration: 25000 nM
Compound 3: middle estimate off by 100-fold (2.00 log units), on the low side, outside the stated range (above it).
By their numbers in this assay, from the lowest: compound 1; then compound 2; then compound 3.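

In this assay the change from amino to hydroxyamino that gives compound 3 reads a 280-fold higher number from compound 1 to compound 3 (2.44 log units; beyond the scatter) and is classed as large, whereas the step at the other amine nitrogen reads a 2.7-fold higher number from compound 1 to compound 2 (0.43 log units; beyond the scatter) and is classed as modest. The same replacement of hydrogen by hydroxy therefore carries no single cost across the two amine nitrogens of compound 1, and the step at one nitrogen gives a poor guide to the step at the other. Within the data shown here, of the two nitrogens compared, the one changed in compound 3 is far less tolerant of this replacement, and no measurement at hand explains the gap between the two steps.

The compounds shown leave open whether this large step is specific to hydroxy or would also follow other replacements of hydrogen on the same nitrogen, such as methyl or methoxy. They also leave open how the core of compound 1 would respond to hydroxy on both nitrogens at once, and whether the two steps would simply add.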